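Anilide Ring Substituent Swap: Estimating Compound 4

This account rests on a few compounds, and the source may have more. Where it says the series, first, only, none or still open, it means among the compounds named here.

Compound 1, `O=C(CSc1nc(Nc2ccccc2)c2ccccc2n1)Nc1ccccc1Br`, gives 19800 nM in a functional assay on PC-3 cells (Homo sapiens) for inhibition, read by MTT assay, with a stated time of 72 h; on this read-out lower numbers stand for stronger inhibition and higher numbers for weaker inhibition.
Compound 2, `O=C(CSc1nc(Nc2ccccc2)c2ccccc2n1)Nc1cccc(Cl)c1`, gives 12600 nM.
Compound 3, `COc1cccc(NC(=O)CSc2nc(Nc3ccccc3)c3ccccc3n2)c1`, gives 11600 nM.

Compound 2 stands second highest of the three numbers in this assay. Its nearest neighbour is compound 3, with a 1.1-fold lower number from compound 2 to compound 3 (0.04 log units; within the scatter); its furthest is compound 1, with a 1.6-fold lower number from compound 1 to compound 2 (0.20 log units; within the scatter). The step to compound 4, `C=CC(=O)Nc1cccc(NC(=O)CSc2nc(Nc3ccccc3)c3ccccc3n2)c1`, is (vinylcarbonyl)amino in place of chloro on an aromatic carbon.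

For the measured compounds named here, three measured steps bear on it, all of them changes on the same anilide ring: a 1.6-fold lower number from compound 1 to compound 2 (0.20 log units; within the scatter), a 1.7-fold lower number from compound 1 to compound 3 (0.23 log units; within the scatter) and a 1.1-fold lower number from compound 2 to compound 3 (0.04 log units; within the scatter). Each of these lies within the scatter, so variation on this ring has so far left the number in this assay essentially unchanged. The entering group is larger than anything tried there, but with no measured step beyond the scatter to point in either direction, compound 4 is expected to land close to compound 2, with a 1.3-fold lower number from compound 2 to compound 4 (0.10 log units; within the scatter) estimated to be within the scatter. Compound 4 is therefore estimated at 10000 nM in this assay, with a range from 3000 nM to 30000 nM.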

Compound 4, half-maximal inhibitory concentration: 8740 nM
For compound 4 the middle estimate is 1.1-fold (0.06 log units) above the measured one; the range from low to high includes it.
By their numbers in this assay, from the lowest: compounds 4, 3, 2 and 1 (each within the scatter of the next, the first and the last beyond it).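

The place on the aromatic ring held by chloro in compound 2 takes the larger (vinylcarbonyl)amino group with every nearby step still inside the scatter in this assay (a 1.4-fold lower number from compound 2 to compound 4 (0.16 log units; within the scatter); a 1.3-fold lower number from compound 3 to compound 4 (0.12 log units; within the scatter)). For the compounds shown here, the first step on this ring to pass the scatter is the modest one against the 2-bromophenyl compound (a 2.3-fold lower number from compound 1 to compound 4 (0.36 log units; beyond the scatter)), and it exchanges the whole 3-((vinylcarbonyl)amino)phenyl group for 2-bromophenyl, so it cannot be assigned to a single feature. Nothing available explains this result.

As far as these compounds go, whether the double bonds of the entering group matter remains open, as a propanoylamino or acetylamino group at this place would be needed to separate the vinyl part from the amide. From the compounds shown here alone, how an amine or a carboxylic acid would read there is also open.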